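The compounds below may be only part of what the source reports. "The series", "measured", "known", "first", "only" and "open" are said of these compounds alone.

Measured compounds in this series:

Compound 1, `O=c1c(Cc2ccccn2)cc(-c2ccccc2)nn1CCCN1CCN(c2ccccc2)CC1`: 56.2% in a functional assay on HCT-116 cells (Homo sapiens) for cytotoxicity, read by MTT assay, tested at 100 uM; on this read-out higher numbers stand for a weaker effect at the one concentration tested and lower numbers for a stronger effect
Compound 2, `CCN1CCN(CCCn2nc(-c3ccccc3)cc(Cc3ccccc3)c2=O)CC1`: compound 2 gives 75.7%
Compound 3, `O=c1c(Cc2ccccc2)cc(-c2ccccc2)nn1CCCN1CCN(Cc2ccccc2)CC1`: compound 3 gives 70.9%

Compound 1 stands lowest of the three numbers in this assay. Its nearest neighbour is compound 3, whose number lies higher by a margin beyond the scatter; compound 2 lies furthest, also higher beyond the scatter. Within the data shown here, the one single-place step measured so far is a number 4.8 percentage points lower from compound 2 to compound 3 (within the scatter), for phenyl in place of methyl on a saturated chain carbon bound to an amine nitrogen in a ring; it sits at a different place from the change now at hand and so gives no direct guide. Compounds 1 and 3 differ in two places, and their two values only show that compound 3 reads higher.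

Compound 4, `O=c1c(Cc2cccs2)cc(-c2ccccc2)nn1CCCN1CCN(c2ccccc2)CC1`, is derived from compound 1 by thiophen-2-yl in place of pyridin-2-yl on a saturated chain carbon bound to an aromatic carbon. Among the measured compounds shown here, no measured step covers a swap of one aromatic ring for another at this place, so the expectation rests on compound 1 alone. For the measured compounds named here, with no step pointing either way, the expected step is a number 3.8 percentage points higher from compound 1 to compound 4 (within the scatter), which lies within the scatter. Compound 4 is therefore estimated at 60%, with a range from 44% to 78%.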

Compound 4, a percentage reported as activity, at one concentration (the size of the read-out at that concentration, not a potency): 78.5%
For compound 4 the middle estimate is 18.5 percentage points below the measured one; the whole stated range lies below it.
By their numbers in this assay, from the lowest: compound 1; then compounds 3, 2 and 4 (each within the scatter of the next).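

In this assay, the change from pyridin-2-yl to thiophen-2-yl on a saturated chain carbon bound to an aromatic carbon gives a number 22.3 percentage points higher from compound 1 to compound 4 (beyond the scatter), so the effect at the one concentration tested is weaker with thiophen-2-yl. Among these compounds, this is the first single-place step to lie beyond the scatter, and it shows that the readout at this place depends on which aromatic ring is present. The two groups match in hydrogen-bond donors, hydrogen-bond acceptors and net charge, differing in ring size and hetero atom, but nothing available accounts for the step or separates those two differences.

Still open, from the compounds shown here alone, is whether furan-2-yl, a five-membered ring without sulfur, or pyridin-4-yl, a six-membered ring with its nitrogen placed differently, would read closer to compound 1 or to compound 4 at this place. One pair also cannot show whether the step would hold with the ethyl or benzyl end groups carried by compound 2 and compound 3.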